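Series notes: methoxy to methyl on the side chain

The compounds below may be only part of what the source reports. "The series", "measured", "known", "first", "only" and "open" are said of these compounds alone.

Measured compounds:
- compound 1 `CCOCCn1c(N2CCN(C)CC2)nc2ccccc21`; in a functional assay on ileum for inhibition of histamine H1 receptor (Cavia porcellus) (a higher number here means a weaker inhibitor, a lower number a stronger inhibitor), compound 1 gives 10 nM.
- compound 2 `CCNCCn1c(N2CCN(C)CC2)nc2ccccc21`; in this assay compound 2 gives 290 nM.
- compound 3 `COCCn1c(N2CCN(C)CC2)nc2ccccc21`; in this assay compound 3 gives 13 nM.

Compound 3 stands second of the three numbers in this assay. Its step to compound 1 is small, a 1.3-fold higher number from compound 1 to compound 3 (0.11 log units; within the scatter), within the scatter, so the two cannot be ordered; the step of a 22-fold lower number from compound 2 to compound 3 (1.35 log units; beyond the scatter) sets it clearly apart from compound 2.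

Compound 4 `CCCn1c(N2CCN(C)CC2)nc2ccccc21` differs from compound 3 by methyl in place of methoxy on a saturated chain carbon, two bonds along the chain from an aromatic nitrogen. Within the data shown here, no measured pair makes this exact change. The step of a 1.3-fold higher number from compound 1 to compound 3 (0.11 log units; within the scatter) shows that trimming the alkoxy chain costs nothing, while a 29-fold higher number from compound 1 to compound 2 (1.46 log units; beyond the scatter) and a 22-fold lower number from compound 2 to compound 3 (1.35 log units; beyond the scatter) show that swapping the ether oxygen for ethylamino costs a great deal. Compound 4 removes the oxygen without putting a nitrogen in its place, a case the measured pairs do not cover. A loss of moderate size in this assay is expected, smaller than the amine step. Compound 4 is estimated at 40 nM, with a range of 10 nM to 200 nM. The expected step is a 3.1-fold higher number from compound 3 to compound 4 (0.49 log units; beyond the scatter).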

Compound 4, half-maximal inhibitory concentration: 380 nM
Beside the measured number, compound 4's estimate is 9.5-fold (0.98 log units) below it, outside the stated range (above it).
By their numbers in this assay, from the lowest: compounds 1 and 3 (each within the scatter of the next); then compounds 2 and 4 (each within the scatter of the next).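

Removing the oxygen does not give a middle case at this position: methyl in place of methoxy produces a large loss in this assay (a 29-fold higher number from compound 3 to compound 4 (1.47 log units; beyond the scatter)), and methyl in place of ethoxy produces a similar one (a 38-fold higher number from compound 1 to compound 4 (1.58 log units; beyond the scatter)). The propyl compound also cannot be separated from the ethylamino compound (a 1.3-fold higher number from compound 2 to compound 4 (0.12 log units; within the scatter)), so among these four compounds, only the two ether chains keep the number low, and the earlier loss with ethylamino need not be specific to that amine. Nothing available here explains this result.

Because the propyl chain is also shorter than either ether chain, the compounds shown do not separate loss of the oxygen from loss of chain length, which a butyl chain could address. From the compounds shown here alone, whether a thioether or a terminal hydroxyl on the same chain would match the ethers also remains open.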